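A Third Aryl Variant on the Shared Core

A few compounds are considered here, and "the series" means these few. Any claim that something is new, unique, unknown or untested is made for them only; others in the source may bear on it.

Compound 1 `COc1cccc(/C=C2\CCC/C(=C\c3cc(OC)c(OC)c(OC)c3)C2=O)c1OC` gives 3900 nM in a functional assay on T84 cells (Homo sapiens) for antiproliferative activity, read by MTT assay, with a stated time of 72 h; a higher number here means a weaker inhibitor, a lower number a stronger inhibitor.
Compound 2 `COc1cc(/C=C2\CCC/C(=C\c3ccc(O)c(O)c3)C2=O)cc(OC)c1OC` gives 3600 nM.
Compound 3 `COc1ccccc1/C=C1\CCC/C(=C\c2cc(OC)c(OC)c(OC)c2)C1=O` gives 2100 nM.

Compound 3 has the lowest of the three numbers, but the step of a 1.9-fold lower number from compound 1 to compound 3 (0.27 log units; within the scatter) and the step of a 1.7-fold lower number from compound 2 to compound 3 (0.23 log units; within the scatter) both lie within the scatter, so the three compounds cannot be told apart on these figures.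

Compound 4 `COc1cc(/C=C2\CCC/C(=C\c3cccc(O)c3)C2=O)cc(OC)c1OC` differs from compound 3 in one place: 3-hydroxyphenyl in place of 2-methoxyphenyl on a double-bonded chain carbon bound to a double-bonded ring carbon. The rest of the molecule is kept.

Two measured steps exchange the aryl group at this same position: a 1.1-fold lower number from compound 1 to compound 2 (0.03 log units; within the scatter) and a 1.7-fold lower number from compound 2 to compound 3 (0.23 log units; within the scatter). A third, a 1.9-fold lower number from compound 1 to compound 3 (0.27 log units; within the scatter), removes a methoxy from an aromatic carbon. None of these leaves the scatter, although together they move between a dimethoxy pattern, a dihydroxy pattern and a single methoxy. On this basis a single hydroxyl in place of the methoxy is not expected to produce a step beyond the scatter in this assay, in either direction.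

Compound 4 is therefore estimated at 2600 nM, within a range of 1200 nM to 5600 nM. The expected step is a 1.2-fold higher number from compound 3 to compound 4 (0.09 log units; within the scatter).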

Compound 4, half-maximal inhibitory concentration: 6500 nM
Estimate against measurement, compound 4: 2.5-fold (0.40 log units) below, outside the stated range (above it).
By their numbers in this assay, from the lowest: compounds 3, 2, 1 and 4 (each within the scatter of the next, the first and the last beyond it).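

For the compounds shown here, at this position, the exchange of 2-methoxyphenyl for 3-hydroxyphenyl on the double-bonded chain carbon bound to a double-bonded ring carbon gives a 3.1-fold higher number from compound 3 to compound 4 (0.49 log units; beyond the scatter) in this assay as the first step to leave the scatter, so the assay does not treat every aryl exchange here alike. The separation holds only for that pair, as the loss of a hydroxy gives a 1.8-fold higher number from compound 2 to compound 4 (0.26 log units; within the scatter) and 3-hydroxyphenyl in place of 2,3-dimethoxyphenyl gives a 1.7-fold higher number from compound 1 to compound 4 (0.22 log units; within the scatter) and so compound 1 and compound 2 cannot be told apart from compound 4. Nothing among the data shown accounts for the modest step between compound 3 and compound 4.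

The compounds shown leave open whether that step follows the loss of the methoxy, the arrival of the hydroxy, or the place each group holds on the aromatic ring. They also leave open what an amine or a carboxylic acid on this aromatic ring would give in this assay when set against the hydroxy of compound 4.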